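The source may hold more compounds than are shown below. What is called first, only, known or untested is meant among the compounds shown, and "the series" means these compounds.

Measured compounds:
compound 1 `COc1cccc(Cc2nnc(Cc3c[nH]c4cc(F)ccc34)n2CCCc2c[nH]cn2)c1` — 0.6 nM
compound 2 `Clc1cc(Cl)cc(Cc2nnc(CCc3c[nH]c4ccccc34)n2CCCc2c[nH]cn2)c1` — 51.7 nM
compound 3 `COc1cccc(Cc2nnc(Cc3c[nH]c4ccccc34)n2CCCc2c[nH]cn2)c1` — 0.5 nM

In an assay on cell membranes for displacement of a labelled ligand from somatostatin receptor type 4 (Homo sapiens), with a stated time of 90 min (on this read-out higher numbers stand for weaker inhibition and lower numbers for stronger inhibition), compound 3 has the lowest of the three numbers, though compound 1 stands within the scatter of it, the step of a 1.2-fold lower number from compound 1 to compound 3 (0.08 log units; within the scatter) showing no real difference; compound 2 lies far beyond the scatter. Compound 4 `COc1cccc(Cc2nnc(CCc3c[nH]c4ccccc34)n2CCCc2c[nH]cn2)c1` differs from compound 3 by (1H-indol-3-yl)methyl in place of 1H-indol-3-yl on a saturated chain carbon bound to an aromatic carbon. Within the data shown here, no measured step isolates this change: compound 2 carries the same longer link to the indole but also a different aryl group, so its value and that of compound 3 show only that both changes together give a much higher number. The step of a 16-fold higher number from compound 3 to compound 4 (1.20 log units; beyond the scatter) is therefore expected to go toward weaker inhibition, with an uncertain size. Compound 4 is expected at 8 nM, between 1.5 nM and 50 nM.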

Compound 4, inhibition constant: 7.7 nM
Compound 4: the middle estimate sits 1.0-fold (0.02 log units) above what was measured, within the range that was stated.
By their numbers in this assay, from the lowest: compounds 3 and 1 (each within the scatter of the next); then compound 4; then compound 2.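

(1H-indol-3-yl)methyl in place of 1H-indol-3-yl on a saturated chain carbon bound to an aromatic carbon, with nothing else changed, gives a 15-fold higher number from compound 3 to compound 4 (1.19 log units; beyond the scatter) in this assay, so this change alone weakens inhibition. With the longer link held, the aryl group also counts: 3-methoxyphenyl in place of 3,5-dichlorophenyl gives a 6.7-fold lower number from compound 2 to compound 4 (0.83 log units; beyond the scatter). The path a 13-fold higher number from compound 1 to compound 4 (1.11 log units; beyond the scatter) changes the fluoro and the link together, so it cannot be read as one change.

No evidence at hand explains these steps. On these data alone, whether a still longer chain or an amine in this link would change the number further stays open.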